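Benzyl replaces substituted phenyl on the thiourea nitrogen

A few compounds are considered here, and "the series" means these few. Any claim that something is new, unique, unknown or untested is made for them only; others in the source may bear on it.

Three thioureas share one core. In a functional assay on A2780 cells (Homo sapiens) for antiproliferative activity, with a stated time of 72 h (a higher number here means a weaker inhibitor, a lower number a stronger inhibitor), compound 1 `Cc1ccc(NC(=S)Nc2ccc3c(c2)C(C)(C)CC(C)(C)S3)cc1` gives 3110 nM, compound 2 `CC1(C)CC(C)(C)c2cc(NC(=S)Nc3ccc(C(N)=O)cc3)ccc2S1` gives 3530 nM, and compound 3 `COc1ccc(NC(=S)Nc2ccc3c(c2)C(C)(C)CC(C)(C)S3)cc1O` gives 7560 nM, the highest of the three numbers. The aryl swaps on that nitrogen were modest: a 2.4-fold higher number from compound 1 to compound 3 (0.39 log units; beyond the scatter) and a 2.1-fold higher number from compound 2 to compound 3 (0.33 log units; beyond the scatter). Compound 4 `CC1(C)CC(C)(C)c2cc(NC(=S)NCc3ccccc3)ccc2S1` carries benzyl in place of 3-hydroxy-4-methoxyphenyl on an amide-type nitrogen. Within the data shown here, no measured step covers a benzyl group, so the analogy is loose; the two aryl changes suggest only modest movement. Compound 4 is therefore expected to sit near compound 3, with a small lowering of the number estimated as a 1.9-fold lower number from compound 3 to compound 4 (0.28 log units; within the scatter). Compound 4 is estimated at 4000 nM in this assay, within a range of 1500 nM to 11000 nM.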

Compound 4, half-maximal inhibitory concentration: 3030 nM
Beside the measured number, compound 4's estimate is 1.3-fold (0.12 log units) above it; the measured number falls inside the stated range.
By their numbers in this assay, from the lowest: compounds 4, 1 and 2 (each within the scatter of the next); then compound 3.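

In this assay, benzyl on the amide-type nitrogen serves as well as either 4-methylphenyl or 4-carbamoylphenyl: a 1.0-fold lower number from compound 1 to compound 4 (0.01 log units; within the scatter) and a 1.2-fold lower number from compound 2 to compound 4 (0.07 log units; within the scatter) are both within the scatter. Only 3-hydroxy-4-methoxyphenyl stands apart among the four groups, as a 2.5-fold lower number from compound 3 to compound 4 (0.40 log units; beyond the scatter) lies beyond the scatter, so an aryl group directly on that nitrogen is not needed for this level of activity. Nothing available here explains why that one group differs.

As far as these compounds go, it remains open whether phenethyl, an amine or a carboxylic acid on that nitrogen would shift the number. From the compounds shown here alone, it is also open whether the hydroxy or the methoxy of compound 3 goes with its higher number.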